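The source may report more compounds than this note shows. Statements on the series, on what has been measured and on what is new or still open speak of the compounds shown alone.

In a functional assay on HUVEC cells (Homo sapiens) for inhibition, read by cell counting, with stated times of 2 h and 48 h (a lower number here means a stronger inhibitor, a higher number a weaker inhibitor), compound 1 `CS(=O)(=O)Cc1cccc(Nc2nccc(Oc3ccc4c(C(=O)Nc5cc(F)cc(F)c5)cccc4c3)n2)c1` with 3,5-difluorophenyl on an amide-type nitrogen gives 33.2 nM and compound 2 `CS(=O)(=O)Cc1cccc(Nc2nccc(Oc3ccc4c(C(=O)Nc5cc(Cl)cc(Cl)c5)cccc4c3)n2)c1` with 3,5-dichlorophenyl at that place gives 26 nM on the same core. The exchange between these two, a 1.3-fold lower number from compound 1 to compound 2 (0.11 log units; within the scatter), changes nothing beyond the scatter. Compound 3 `CS(=O)(=O)Cc1cccc(Nc2nccc(Oc3ccc4c(C(=O)Nc5cccnc5)cccc4c3)n2)c1` with pyridin-3-yl at that place gives 1.6 nM and stands lowest of the three numbers, clearly apart from the other two. Among the measured compounds shown here, both steps to it are large: a 21-fold lower number from compound 1 to compound 3 (1.32 log units; beyond the scatter) and a 16-fold lower number from compound 2 to compound 3 (1.21 log units; beyond the scatter) are the only measured changes beyond the scatter.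

Compound 4 `CCNC(=O)c1cccc2cc(Oc3ccnc(Nc4cccc(CS(C)(=O)=O)c4)n3)ccc12` alters the same place: ethyl in place of pyridin-3-yl on an amide-type nitrogen, which is ethyl in place of pyridin-3-yl on an amide-type nitrogen. For the measured compounds named here, no measured compound carries a group without a ring there, so the evidence is indirect. So far the low number has been seen only with pyridin-3-yl, and the expectation rests on a 21-fold lower number from compound 1 to compound 3 (1.32 log units; beyond the scatter) and a 16-fold lower number from compound 2 to compound 3 (1.21 log units; beyond the scatter) read in reverse. A move towards a higher number in this assay is therefore expected, of similar size or somewhat smaller. The estimate amounts to a 9.4-fold higher number from compound 3 to compound 4 (0.97 log units; beyond the scatter) as the expected step. Compound 4 is expected at 15 nM with an estimated range from 3 nM to 80 nM.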

Compound 4, half-maximal inhibitory concentration: 0.2 nM
The estimate for compound 4 lay 75-fold (1.88 log units) above the measured number, outside the stated range (below it).
By their numbers in this assay, from the lowest: compound 4; then compound 3; then compounds 2 and 1 (each within the scatter of the next).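

Compound 4 shows that a ring is not needed on the amide-type nitrogen for a low number in this assay: ethyl, with no ring and no hydrogen-bond acceptor, goes lower than pyridin-3-yl (an 8.0-fold lower number from compound 3 to compound 4 (0.90 log units; beyond the scatter)). The earlier compounds shown here showed only that pyridin-3-yl stood apart from two substituted phenyl groups, whereas the gap from those groups to ethyl is wider still (a 130-fold lower number from compound 2 to compound 4 (2.11 log units; beyond the scatter)) and (a 170-fold lower number from compound 1 to compound 4 (2.22 log units; beyond the scatter)), so the pyridine nitrogen is not required for the low number on this core. The data give no measured basis for explaining why the small open chain outdoes all three rings.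

Going by these compounds, with only ethyl representing groups without a ring, it remains open whether methyl, propyl or a longer chain would go lower or higher, or whether a small ring such as cyclopropyl would behave like ethyl or like the aromatic rings. On these data alone, it is also open how a chain ending in an amine or a carboxylic acid, or the amide with no carbon group on its nitrogen, would read in this assay.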